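Hydroxyphenyl placement on a shared pyridine-free core series

The source may hold more compounds than are shown below. What is called first, only, known or untested is meant among the compounds shown, and "the series" means these compounds.

Measured so far:
compound 1, `Oc1ccc(-c2cc(-c3ccccc3O)cc(-c3ccccc3O)n2)cc1`, 360 nM
compound 2, `Oc1ccc(-c2cc(-c3cccc(O)c3)nc(-c3ccccc3O)c2)cc1`, 3420 nM

In a functional assay on DU-145 cells (Homo sapiens) for cytotoxicity, read by CCK-8 assay, with a stated time of 4 days (a lower number here means a stronger inhibitor, a higher number a weaker inhibitor), compound 2 gives 3420 nM, the highest of the two numbers; compound 1 gives 360 nM, and that gap lies beyond the scatter. Compound 3, `Oc1cccc(-c2cc(-c3ccccc3O)cc(-c3ccccc3O)n2)c1`, has not been measured. It differs from compound 2 by 2-hydroxyphenyl in place of 4-hydroxyphenyl on an aromatic carbon, so that compound 3 carries two 2-hydroxyphenyl groups as compound 1 does. Going by the values given here, with no measured step between compounds, the change from compound 2 to compound 3 is expected to lower the number by a 3.4-fold lower number from compound 2 to compound 3 (0.53 log units; beyond the scatter), because compound 1 gives 360 nM. Compound 3 is therefore estimated at 1000 nM, between 300 nM and 3500 nM.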

Compound 3, half-maximal inhibitory concentration: 3980 nM
Compound 3: middle estimate off by 4.0-fold (0.60 log units), on the low side; the whole stated range lies below it.
By their numbers in this assay, from the lowest: compound 1; then compounds 2 and 3 (each within the scatter of the next).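

In this assay, 2-hydroxyphenyl in place of 4-hydroxyphenyl opposite the ring nitrogen gives a 1.2-fold higher number from compound 2 to compound 3 (0.07 log units; within the scatter), so with a 3-hydroxyphenyl group on the core this exchange has no visible effect. By contrast, 3-hydroxyphenyl in place of 4-hydroxyphenyl gives an 11-fold higher number from compound 1 to compound 3 (1.04 log units; beyond the scatter), so with two 2-hydroxyphenyl groups on the core, the 4-hydroxyphenyl group is tied to the lower number of compound 1. Nothing available explains this difference. Going by these compounds, it remains open whether a methoxy group or an amine could replace the hydroxyl of that 4-hydroxyphenyl group and keep the number of compound 1.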